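Iodo in place of ethynyl: notes on compound 4

The source may report more compounds than this note shows. Statements on the series, on what has been measured and on what is new or still open speak of the compounds shown alone.

Measured in a functional assay on HCT-116 cells (Homo sapiens) for cytotoxicity, with a stated time of 3 days (on this read-out lower numbers stand for stronger inhibition and higher numbers for weaker inhibition), as follows
- compound 1 (`C#Cc1sc(-c2ccc(F)cc2)nc1C(=O)OCC`) gives > 40000 nM
- compound 2 (`C#Cc1nc2ccccc2s1`) gives 19600 nM
- compound 3 (`Cn1c(I)nc2ccccc21`) gives 17500 nM

In this assay compound 2 at 19600 nM and compound 3 at 17500 nM lie within the scatter of each other. Compound 1 reaches only a limit (> 40000 nM) and no number.

Compound 4 (`Ic1nc2ccccc2s1`) has iodo in place of ethynyl on an aromatic carbon of the shared core. For the measured compounds named here, no measured pair shows this change, but compound 3 also carries iodo and gives 17500 nM on its own core, so no step beyond the scatter is expected in this assay for this change. The estimated 1.0-fold higher number from compound 2 to compound 4 (0.01 log units; within the scatter) stays within the scatter. For compound 4 the expected value is 20000 nM with an estimated range of 8000 nM to 40000 nM in this read-out.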

Compound 4, half-maximal inhibitory concentration: > 40000 nM
Compound 4 gave a limit, no number (the forecaster's own chance of this, stated with the estimate: 20%); middle value at least 2.0-fold (0.30 log units) away from the limit.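

In this assay, iodo in place of ethynyl on an aromatic carbon, next to the ring nitrogen and next to the ring sulfur, gives an at least 2.0-fold higher number from compound 2 to compound 4 (0.30 log units; that floor lies within the scatter). Compound 4 gives > 40000 nM, which is a limit and not a number, so only a floor for this step can be read: the limit of > 40000 nM in this assay, at which 2 of the 4 values shown sit.

For the compounds shown here, on the shared core, ethynyl is thus the only group here with a number at this position. On these data alone, whether an amine or a carboxylic acid at this position would give a number in this read-out stays open, as does the true value of compound 4.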